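The compounds below may be only part of what the source reports. "The series", "measured", "known", "first", "only" and "open" are said of these compounds alone.

Measured compounds:
Compound 1 `CN(C)C(=O)N(Cc1ccco1)Cc1cc(Cl)ccc1O` gives 49500 nM
Compound 2 `CCOC(=O)N1CCC(N(Cc2cc(Cl)ccc2O)C(=O)N(C)C)CC1` gives 25700 nM
Compound 3 `CN(C)C(=O)N(Cc1ccco1)Cc1cc([N+](=O)[O-])ccc1O` gives 20800 nM

These values come from a functional assay on KB cells (Homo sapiens) for antiproliferative activity, read by MTT assay, with a stated time of 48 h; on this read-out higher numbers stand for weaker inhibition and lower numbers for stronger inhibition. Compound 1 and compound 3 share one core and differ in a single place: nitro in place of chloro on an aromatic carbon That change gave a 2.4-fold lower number from compound 1 to compound 3 (0.38 log units; beyond the scatter). Compound 2 and the not yet measured compound 4 `CCOC(=O)N1CCC(N(Cc2cc([N+](=O)[O-])ccc2O)C(=O)N(C)C)CC1` share another core; the difference between the two cores is not broken down here. The value of compound 2 lies within the scatter of both compound 1 and compound 3, so no order among them can be claimed. The change to compound 4 is the same: nitro in place of chloro on an aromatic carbon The expected step is a 2.2-fold lower number from compound 2 to compound 4 (0.35 log units; beyond the scatter), a size that rests on the earlier step because the same change in this assay gave a 2.4-fold lower number from compound 1 to compound 3 (0.38 log units; beyond the scatter). Compound 4 is therefore estimated at 11500 nM, with a likely range from 5000 nM to 28000 nM.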

Compound 4, half-maximal inhibitory concentration: 24200 nM
Beside the measured number, compound 4's estimate is 2.1-fold (0.32 log units) below it; low and high end bracket the measured number.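

Nitro in place of chloro on an aromatic carbon gave a 1.1-fold lower number from compound 2 to compound 4 (0.03 log units; within the scatter), so on this core the swap has no effect that can be told apart from the scatter. Set beside the step on the other core, this result does not differ from it either: the same change on two cores in this assay, a 2.4-fold lower number (0.38 log units; beyond the scatter) from compound 1 to compound 3 and a 1.1-fold lower number (0.03 log units; within the scatter) from compound 2 to compound 4, 2.2-fold (0.35 log units) apart, within the scatter of two such steps

Two pairs therefore neither show that the step seen on the core of compound 1 carries over to the core of compound 2 nor show that it is lost.

Open, from the compounds shown here alone, is whether an amine or a nitrile in place of the chloro would give a step beyond the scatter on both cores. Also open, going by these compounds, is whether more pairs would show the core to matter at all.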